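Adding a 4-methoxybenzyl group to compound 1

The source may hold more compounds than are shown below. What is called first, only, known or untested is meant among the compounds shown, and "the series" means these compounds.

Compound 1 `N#C/C(=C\c1c[nH]c2ccccc12)C(=O)c1c[nH]c2ccccc12`: 36800 nM
Compound 2 `COc1ccc(-c2[nH]c3ccccc3c2/C=C(\C#N)C(=O)c2c[nH]c3ccccc23)cc1`: > 50000 nM (a limit)
Compound 3 `COc1ccc2c(C(=O)/C(C#N)=C/c3c[nH]c4ccccc34)c[nH]c2c1`: > 50000 nM (a limit)

For the measured compounds named here, in a functional assay on MIA PaCa-2 cells (Homo sapiens) for cytotoxicity, read by WST assay, with a stated time of 48 h (a higher number here means a weaker inhibitor, a lower number a stronger inhibitor), compound 1 gives 36800 nM, the only exact number here. The other two results are limits. Compound 4 `COc1ccc(Cn2cc(/C=C(\C#N)C(=O)c3c[nH]c4ccccc34)c3ccccc32)cc1` changes the core of compound 1: 4-methoxybenzyl in place of hydrogen on an aromatic nitrogen. Going by the values given here, two measured steps bear on this, both adding a group on an aromatic carbon: an at least 1.3-fold higher number from compound 1 to compound 2 (0.13 log units; that floor lies within the scatter) and an at least 1.3-fold higher number from compound 1 to compound 3 (0.13 log units; that floor lies within the scatter). Each gives only a floor, so neither shows a real change. No step beyond the scatter is therefore expected in this assay. The expected step is a 1.1-fold lower number from compound 1 to compound 4 (0.05 log units; within the scatter). Compound 4 is estimated at 33000 nM, within an expected range of 10000 nM to 60000 nM.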

Compound 4, half-maximal inhibitory concentration: > 50000 nM
Compound 4: a limit, no number (the forecaster's own chance of this, stated with the estimate: 40%); middle value at least 1.5-fold (0.18 log units) from the limit.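

In this assay compound 4 gives a limit and not a number, so a change on the aromatic nitrogen ends the same way as the two changes on aromatic carbons. The change gives an at least 1.3-fold higher number from compound 1 to compound 4 (0.13 log units; that floor lies within the scatter), so no real shift can be read, though a larger one is not excluded. Compound 4 therefore adds a new position to the pattern, and its result sits with the others at the same ceiling: the limit of > 50000 nM in this assay, at which 3 of the 4 values shown sit.

From the compounds shown here alone, whether a methyl group or an aminoethyl chain on this nitrogen would give an exact number remains open.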